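Ring substituent at the ether oxygen: compounds 3 and 4

A few compounds are considered here, and "the series" means these few. Any claim that something is new, unique, unknown or untested is made for them only; others in the source may bear on it.

Measured so far:
compound 1 `CNC(=O)c1cccc(Cn2nc(C)c(NC(=O)c3ccc(COC4CCCCC4)cc3)c2C)c1` — 14000 nM
compound 2 `CNC(=O)c1cccc(Cn2nc(C)c(NC(=O)c3ccc(COc4cccc(C)c4)cc3)c2C)c1` — 6200 nM
compound 3 `CNC(=O)c1cccc(Cn2nc(C)c(NC(=O)c3ccc(COc4ccc(C)cc4)cc3)c2C)c1` — 2600 nM

In a functional assay on MIA PaCa-2 cells (Homo sapiens) for antiproliferative activity, read by MTT assay, with a stated time of 72 h (a higher number here means that more compound is needed for the effect, a lower number that less compound is needed), compound 3 gives the lowest of the three numbers, with compound 2 nearest and compound 1 furthest. Both gaps are beyond the scatter: a 2.4-fold lower number from compound 2 to compound 3 (0.38 log units; beyond the scatter) and a 5.4-fold lower number from compound 1 to compound 3 (0.73 log units; beyond the scatter). For the measured compounds named here, the one other step, a 2.3-fold lower number from compound 1 to compound 2 (0.35 log units; beyond the scatter), shows that an aryl group on the ether oxygen lowers the number relative to cyclohexyl, and that where the methyl sits on that aryl ring matters.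

Compound 4 `CNC(=O)c1cccc(Cn2nc(C)c(NC(=O)c3ccc(COc4ccccc4OC)cc3)c2C)c1` carries the change (2-methoxyphenyl in place of 4-methylphenyl on an oxygen on a saturated carbon). Going by the values given here, no measured step touches a methoxy group or a substituent placed as in 2-methoxyphenyl, so the bearing is indirect. The steps to compound 3 suggest that moving away from 4-methylphenyl costs something of the size seen in a 2.4-fold lower number from compound 2 to compound 3 (0.38 log units; beyond the scatter), while the aryl ring itself is kept. A modest rise in the number in this assay is therefore expected for compound 4, roughly a 2.1-fold higher number from compound 3 to compound 4 (0.33 log units; beyond the scatter). The value for compound 4 is estimated at 5500 nM, within a range of 2200 nM to 14000 nM.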

Compound 4, half-maximal effective concentration: 8500 nM
For compound 4 the middle estimate is 1.5-fold (0.19 log units) below the measured one; measured number inside the range.
By their numbers in this assay, from the lowest: compound 3; then compounds 2, 4 and 1 (each within the scatter of the next, the first and the last beyond it).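

In this assay, the aryl ring alone does not set the value at this position: 2-methoxyphenyl in place of 4-methylphenyl gives a step beyond the scatter (a 3.3-fold higher number from compound 3 to compound 4 (0.51 log units; beyond the scatter)). Compound 4 stays within the scatter of both compound 2 (a 1.4-fold higher number from compound 2 to compound 4 (0.14 log units; within the scatter)) and compound 1 (a 1.6-fold lower number from compound 1 to compound 4 (0.22 log units; within the scatter)), so the aryl ring of compound 4 cannot be separated from cyclohexyl here, which narrows the earlier reading that an aryl group lowers the number. Compound 3 remains the only compound with steps beyond the scatter to all the others, so the advantage shown here belongs to 4-methylphenyl, not to aryl groups in general.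

Still open, as far as these compounds go, is how far the step from compound 3 to compound 4 reflects the change of group and how far its placing on the ring, and how an unsubstituted phenyl, an amine or a carboxylic acid on this ring would read. No available evidence bears on the cause of these steps.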